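A few compounds are considered here, and "the series" means these few. Any claim that something is new, unique, unknown or untested is made for them only; others in the source may bear on it.

Compound 1, `CCCOC(=O)C1=C(C)NC(=O)NC1c1ccco1`, gives 3% in an assay on membranes from HeLa cells for displacement of a labelled ligand from adenosine receptor A3 (Homo sapiens), read by scintillation counting, with a stated time of 180 min, tested at 1 uM; a higher number here means more inhibition at the concentration tested (going by the name of the read-out), a lower number less inhibition.
Compound 2, `CCCOC(=O)C1=C(C)NC(=O)NC1c1ccoc1`, gives 11% in this assay.
Compound 3, `CCCOC(=O)C1=C(C)N(C)C(=O)NC1c1ccco1`, gives 8% in this assay.

Compound 3 stands second highest of these three numbers. Its nearest neighbour is compound 2, whose value sits within the usual scatter of that of compound 3, so the two cannot be told apart. The other comparison is a single change: a number 5 percentage points higher from compound 1 to compound 3 (within the scatter), again within the scatter. All three compounds therefore show only weak inhibition at the concentration tested.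

Compound 4, `CC1=C(C(=O)OC(C)(C)C)C(c2ccco2)NC(=O)N1C`, differs from compound 3 in one place: tert-butyl in place of propyl on an oxygen next to a carbonyl group. Within the data shown here, none of the measured steps touches this part of the molecule. The two steps that are known, a number 8 percentage points higher from compound 1 to compound 2 (within the scatter) and a number 5 percentage points higher from compound 1 to compound 3 (within the scatter), both alter other positions and both stay within the scatter, so they give no direction for the present change. With nothing pointing up or down, the expected step is no change at the digits printed from compound 3 to compound 4 (within the scatter), that is, no change beyond the scatter. Compound 4 is accordingly estimated at 8%, with a range from 0% to 20%.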

Compound 4, a percentage reported as inhibition, at one concentration (the size of the read-out at that concentration, not a potency): 54%
Estimate against measurement, compound 4: 46 percentage points below; the measured number lies above the stated range.
By their numbers in this assay, from the lowest: compounds 1, 3 and 2 (each within the scatter of the next); then compound 4.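

In this assay, the group on an oxygen next to a carbonyl group proves to be a sensitive place: tert-butyl in place of propyl gives a number 46 percentage points higher from compound 3 to compound 4 (beyond the scatter), with the rest of the molecule unchanged. The two earlier steps, at other positions, stayed within the scatter, so this is the first change shown that clearly moves the number. No measurement available here explains why this swap has such a large effect.

The compounds shown do not tell whether the rise is special to tert-butyl or would also appear with isopropyl, a butyl chain or a cyclohexyl group on the same oxygen. They also leave open whether tert-butyl gives a similar rise with the amide hydrogen of compound 1 or the furan-3-yl group of compound 2.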